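Weak Growth Inhibition Across One Shared Core

The compounds below may be only part of what the source reports. "The series", "measured", "known", "first", "only" and "open" are said of these compounds alone.

Of the compounds shown here, three built on one shared core have been measured in a functional assay on PC-3 cells (Homo sapiens) for inhibition, read by MTT assay, with a stated time of 72 h, tested at 1 uM; a lower number here means less inhibition of growth, a higher number more inhibition of growth at the concentration tested. Compound 1, `COc1cc2ncnc(Nc3cc(C(F)(F)F)ccc3F)c2c(OC)c1OC`, gives 7.6% in this assay. Compound 3, `COc1cc2ncnc(Nc3c(F)cc(F)cc3Br)c2c(OC)c1OC`, gives 8.1%. Compound 2, `COc1cc2ncnc(Nc3ccc(Br)cc3Cl)c2c(OC)c1OC`, gives -8.4%, the lowest of the three numbers; its nearest neighbour is compound 1, which lies higher by an amount beyond the usual scatter, and compound 3 lies higher by a similar amount, also beyond the scatter. All three numbers sit close to zero, so none of these compounds slows the growth of the cells much at the concentration used.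

Compound 4, `COc1cc2ncnc(Nc3ccccc3F)c2c(OC)c1OC`, has not yet been measured. It differs from compound 2 in one place: 2-fluorophenyl in place of 4-bromo-2-chlorophenyl on a nitrogen on an aromatic ring. Within the data shown here, no measured pair shows the effect of such a swap directly. A small step is expected because compound 3 gives 8.1% with a quite different substitution pattern and still lands near the other two. The step is therefore expected to be small and upward, a number 11.4 percentage points higher from compound 2 to compound 4 (beyond the scatter), close to the edge of the scatter. The value of compound 4 in this assay is estimated at 3%, with a range from -10% to 16%.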

Compound 4, percent growth inhibition at one concentration: 0.9%
The estimate for compound 4 lay 2.1 percentage points above the measured number; the range from low to high includes it.
By their numbers in this assay, from the lowest: compounds 2, 4, 1 and 3 (each within the scatter of the next, the first and the last beyond it).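

Among these compounds, replacing 4-bromo-2-chlorophenyl with 2-fluorophenyl on a nitrogen on an aromatic ring gives a number 9.3 percentage points higher from compound 2 to compound 4 (within the scatter) in this assay, so the first direct comparison at this position shows no change that can be told apart from ordinary repeat-to-repeat variation, even though the bromine and chlorine both leave and a fluorine enters. Hydrogen in place of trifluoromethyl on an aromatic carbon gives a number 6.7 percentage points lower from compound 1 to compound 4 (within the scatter), which means that a second, different change on this aromatic ring also stays inside that variation, and compound 4 therefore links two earlier compounds without separating itself from either one. These two steps record only the size of each change, and nothing available here explains why either is so small.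

As far as these compounds go, the groups compared on this ring are only halogens and trifluoromethyl, so it remains open whether an amine, a carboxylic acid or a longer chain such as butoxy in the same place would move the number beyond the usual variation. From the compounds shown here alone, it also remains open whether any change to this ring can produce clear growth inhibition in this assay at all.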